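The source may report more compounds than this note shows. Statements on the series, on what has been measured and on what is new or still open speak of the compounds shown alone.

Going by the values given here, compound 1, `COc1cccc2occ(Cc3coc4ccccc4c3=O)c(=O)c12`, is the weaker of the two compounds measured so far in a functional assay on NUGC-3 cells (Homo sapiens) for antiproliferative activity, read by XTT assay; on this read-out higher numbers stand for weaker inhibition and lower numbers for stronger inhibition: compound 1 gives 3190 nM, the higher of the two numbers. The other measured compound, compound 2, `COc1ccc2c(=O)c(Cc3coc4cccc(OCC5CCCCC5)c4c3=O)coc2c1`, gives 1440 nM in this assay, and the gap between the two lies beyond the usual scatter of the measurement. Among the compounds with values here, no single-point change connects these two compounds, so their values show only that compound 2 reaches the lower number.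

The step under study leads from compound 1 to compound 3, `O=c1c(Cc2coc3ccccc3c2=O)coc2ccccc12`. The change is hydrogen in place of methoxy on an aromatic carbon. Within the data shown here, no measured pair shows the effect of this change on the shared core, so the expectation rests on compound 1 alone. The step is expected to be small, a 1.3-fold higher number from compound 1 to compound 3 (0.10 log units; within the scatter), with no clear direction beyond the scatter. For compound 3 the estimate in this assay is 4000 nM, expected to fall between 1500 nM and 11000 nM.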

Compound 3, half-maximal inhibitory concentration: 7770 nM
Compound 3: middle estimate off by 1.9-fold (0.29 log units), on the low side; the measured number falls inside the stated range.
By their numbers in this assay, from the lowest: compound 2; then compound 1; then compound 3.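

In this assay, going by these compounds alone, hydrogen in place of methoxy on an aromatic carbon gives a 2.4-fold higher number from compound 1 to compound 3 (0.39 log units; beyond the scatter), the first single-change step. It shows that this place on the ring, ortho to a fused ring and meta to a fused ring, is not indifferent to the change: the methoxy-bearing compound has the lower number, and losing the methoxy weakens inhibition by more than the usual scatter. Nothing available accounts for the size or direction of this step.

From the compounds shown here alone, compound 1 and compound 3 compare only methoxy with hydrogen, so it remains open how a fluorine, an amine or a longer alkoxy chain would read at this place. Going by these compounds, compound 2 differs from both in more than one place, so whether the same step holds on its core also remains open.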